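Prop-1-en-1-yl for vinyl on the amide of compound 2

This account rests on a few compounds, and the source may have more. Where it says the series, first, only, none or still open, it means among the compounds named here.

Measured so far:
compound 1 `O=C(Nc1ccc(Cl)cc1)c1cc([N+](=O)[O-])ccc1Cl` — > 25000 nM
compound 2 `C=CC(=O)Nc1cccc(-c2nc3ccccc3s2)c1` — > 25000 nM

In an ADME assay on Raji cells (Homo sapiens) for inhibition, with a stated time of 72 h (a higher number here means that more compound is needed for the effect, a lower number that less compound is needed), compound 2 reaches only a limit, > 25000 nM. Compound 1 likewise gives only a limit in this assay, > 25000 nM. Within the data shown here, both values sit at the limit of > 25000 nM in this assay, at which 2 of the 2 values shown sit, so no measured step exists.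

Compound 3 `C/C=C/C(=O)Nc1cccc(-c2nc3ccccc3s2)c1` differs from compound 2 by prop-1-en-1-yl in place of vinyl on a carbonyl carbon. Among the measured compounds shown here, with no measured step to draw on, no movement beyond the scatter is expected in this assay. Compound 3 is expected at 30000 nM (range 10000 nM to 100000 nM), most probably reported again as a limit. The expected step is a step that the limit leaves unreadable from compound 2 to compound 3.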

Compound 3, half-maximal effective concentration: > 25000 nM
Compound 3: no number, only a limit; the forecaster's own chance of this, stated with the estimate: 80%; the middle value is on the limit's open side.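

In this assay compound 3 gives > 25000 nM, a limit. Compound 2 gives > 25000 nM, also a limit, and no step can be read between these two compounds. The compounds shown leave open whether any change in the series gives a readable number, as all rest on one limit: the limit of > 25000 nM in this assay, at which 3 of the 3 values shown sit.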